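The source may hold more compounds than are shown below. What is called first, only, known or untested is meant among the compounds shown, and "the series" means these compounds.

Measured compounds in a functional assay (strain AB) with Danio rerio as the target, read by microscopy, with a stated time of 1 h; a higher number here means that more compound is needed for the effect, a lower number that less compound is needed:
Compound 1 `CCN1CCc2c(sc(NC(=O)Nc3ccc(Cl)cc3)c2C(=O)NC)C1` gives only a limit, > 25000 nM.
Compound 2 `CC(C)(C)OC(=O)CCC[N+]1(C)CCc2c(sc(NC(=O)Nc3ccc(Cl)cc3)c2C(N)=O)C1` gives 250 nM.
Compound 3 `CCN1CCc2c(sc(NC(=O)Nc3ccc(Cl)cc3)c2C(=O)NCCO)C1` gives 9400 nM.

Compound 2 stands lowest of the two numbers in this assay; compound 3 sits well above it, and the value of compound 1 is a limit of the assay and not a number, so the series gives two numbers and one limit (the limit of > 25000 nM in this assay, at which 1 of the 3 values shown sits).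

For the measured compounds named here, the one measured step that can be read runs from compound 1 to compound 3: an at least 2.6-fold lower number from compound 1 to compound 3 (0.42 log units; beyond the scatter), a change at the amide side of the shared core. It says nothing about the chain on the ring nitrogen, which is where compound 4 `COCCC[N+]1(C)CCc2c(sc(NC(=O)Nc3ccc(Cl)cc3)c2C(N)=O)C1` differs from compound 2: methoxy in place of tert-butoxycarbonyl on a saturated chain carbon, three bonds along the chain from an amine nitrogen in a ring. Going by the values given here, no measured pair varies this chain, so there is nothing to scale the step against. The expectation rests on the unchanged remainder of compound 2 and its value of 250 nM, and the step is estimated as a 1.2-fold higher number from compound 2 to compound 4 (0.08 log units; within the scatter), within the scatter. Compound 4 is therefore expected to give about 300 nM in this assay, with a range from 100 nM to 900 nM.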

Compound 4, half-maximal effective concentration: 480 nM
For compound 4 the middle estimate is 1.6-fold (0.20 log units) below the measured one; measured number inside the range.
By their numbers in this assay, from the lowest: compounds 2 and 4 (each within the scatter of the next); then compound 3. At a limit, above all of these: compound 1.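

For the compounds shown here, this is the first measured step on the chain at the ring nitrogen: in this assay, the step is a 1.9-fold higher number from compound 2 to compound 4 (0.28 log units; within the scatter). The tert-butoxycarbonyl group, with 7 heavy atoms and 1 double bond, gives way to methoxy, with 2 heavy atoms and no double bond, and the two compounds cannot be told apart in this assay, so on this pair neither the carbonyl nor the bulk of the tert-butyl end is needed to hold a value in this range. No measurement shown accounts for how little this change does.

Going by these compounds, with only the 3-(tert-butoxycarbonyl)propyl and 3-methoxypropyl chains on this nitrogen, and both ends carrying oxygen, it remains open whether the position would accept an end such as a carboxylic acid, a primary amine or a plain alkyl chain, or a longer or shorter chain. Compounds 2 and 4 also differ from compounds 1 and 3 in more than one place, so the gap between these pairs cannot be assigned to the ring nitrogen substituent or to the amide side of the shared core.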